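A pyrimidin-2-yl swap on the ring nitrogen

The source may report more compounds than this note shows. Statements on the series, on what has been measured and on what is new or still open speak of the compounds shown alone.

Of the compounds shown here, three sharing one core have been measured. In a functional assay on HT-29 cells (Homo sapiens) for antiproliferative activity, read by MTT assay, with a stated time of 72 h (on this read-out lower numbers stand for stronger inhibition and higher numbers for weaker inhibition), compound 1 (`Nc1nc(N)c2cc(CSC(=S)N3CCN(C4CCCCC4)CC3)ccc2n1`) gives 4050 nM, compound 2 (`Cc1ccccc1N1CCN(C(=S)SCc2ccc3nc(N)nc(N)c3c2)CC1`) gives 2950 nM and compound 3 (`Nc1nc(N)c2cc(CSC(=S)N3CCN(c4ccc(F)cc4F)CC3)ccc2n1`) gives 5020 nM. These numbers lie within the usual scatter of one another, so compound 3 does not stand apart from the other two.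

Compound 4 (`Nc1nc(N)c2cc(CSC(=S)N3CCN(c4ncccn4)CC3)ccc2n1`) has pyrimidin-2-yl in place of 2,4-difluorophenyl on an amine nitrogen in a ring. Going by the values given here, no measured compound carries pyrimidin-2-yl, so the data hold no direct precedent. The closest guide is the three changes already made at this same nitrogen: a 1.4-fold lower number from compound 1 to compound 2 (0.14 log units; within the scatter), a 1.2-fold higher number from compound 1 to compound 3 (0.09 log units; within the scatter) and a 1.7-fold higher number from compound 2 to compound 3 (0.23 log units; within the scatter). All three are small, so no shift beyond the scatter is expected in this assay.

The expected step is a 1.3-fold lower number from compound 3 to compound 4 (0.10 log units; within the scatter). The estimate for compound 4 is 4000 nM, with an expected range of 1800 nM to 9000 nM.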

Compound 4, half-maximal inhibitory concentration: 4720 nM
Compound 4: the middle estimate sits 1.2-fold (0.07 log units) below what was measured; low and high end bracket the measured number.
By their numbers in this assay, from the lowest: compounds 2, 1, 4 and 3 (each within the scatter of the next).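

With pyrimidin-2-yl the group on this ring nitrogen is no longer limited to rings of carbon only, yet in this assay the read-out does not move beyond the scatter: a 1.1-fold lower number from compound 3 to compound 4 (0.03 log units; within the scatter), a 1.6-fold higher number from compound 2 to compound 4 (0.20 log units; within the scatter) and a 1.2-fold higher number from compound 1 to compound 4 (0.07 log units; within the scatter). Even a change from 0 to 2 hydrogen-bond acceptors in this group, with a ring of 6 heavy atoms entering for one of 8, therefore leaves no visible mark on the antiproliferative read-out. Nothing available here offers a reason for this flat result.

On these data alone, all four compounds carry a six-membered ring on this nitrogen, so the effect of a small methyl group, an acetyl group or a longer chain ending in a carboxylic acid remains open. As far as these compounds go, it is also open whether a change to the shared core would shift the number beyond the scatter.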